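Sulfanyl bromopyrimidine swap from compound 1 to compound 4

The source may report more compounds than this note shows. Statements on the series, on what has been measured and on what is new or still open speak of the compounds shown alone.

In a functional assay on Panc1005 cells (Homo sapiens) for cytotoxicity, read by MTT assay (a higher number here means a weaker inhibitor, a lower number a stronger inhibitor), compound 1 (`O=C(NC(=S)Nc1ccc(Oc2ncccn2)cc1)c1ccccc1`) stands at "not determined" (no result reported), so it offers no single number as a starting point. Compound 2 (`O=C(NC(=O)c1ccccc1)Nc1ccc(Oc2ncc(Br)cn2)cc1`) is also without a number, at "not determined" (no result reported). Compound 3 (`O=C(NC(=O)c1ccccc1)Nc1ccc(Sc2ncc(Br)cn2)cc1`) reads > 10000 nM, which is a limit and not a number. The only anchor in the series is therefore (the limit of > 10000 nM in this assay, at which 1 of the 3 values shown sits).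

The compound still to be measured is compound 4 (`O=C(NC(=S)Nc1ccc(Sc2ncc(Br)cn2)cc1)c1ccccc1`). The change followed here is (5-bromopyrimidin-2-yl)sulfanyl in place of (pyrimidin-2-yl)oxy on an aromatic carbon, with (5-bromopyrimidin-2-yl)sulfanyl in place of (pyrimidin-2-yl)oxy on an aromatic carbon, para to a large group. For the measured compounds named here, no measured step in this assay covers this change, and the size of the step cannot be read from compound 1. A large move toward strong inhibition is not expected, and the expectation rests only on compound 3 at > 10000 nM, a limit. For compound 4 the estimated half-maximal inhibitory concentration is 9000 nM, with an expected range of 2500 nM to 30000 nM.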

Compound 4, half-maximal inhibitory concentration: > 10000 nM
Compound 4: a limit, no number; the forecaster's own chance of this, stated with the estimate: 50%; at least 1.1-fold (0.04 log units) between middle value and limit.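

No step can be read from compound 1 to compound 4: compound 1 carries no single number in this assay, and compound 4 gives > 10000 nM, which is a limit and not a number. The compounds shown leave open how far any single change shifts the half-maximal inhibitory concentration, with the readings resting on one limit: the limit of > 10000 nM in this assay, at which 2 of the 4 values shown sit.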